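Lengthening a hydroxyalkyl chain on a curcuminoid enaminone

A few compounds are considered here, and "the series" means these few. Any claim that something is new, unique, unknown or untested is made for them only; others in the source may bear on it.

The measured compounds:
compound 1, `COc1cc(/C=C/C(=O)/C=C(/C=C/c2ccc(O)c(OC)c2)NCCO)ccc1O`, 93.5%
compound 2, `COCCCN1C(/C=C/c2ccc(O)cc2)=CC(=O)CC1c1ccc(O)cc1`, 97.8%
compound 3, `O=C(/C=C(/C=C/c1ccc(O)cc1)NCCCO)/C=C/c1ccc(O)cc1`, 86.4%

All three were tested in an ADME assay on CHO-K1 cells (Cricetulus griseus) for activation, read by fluorescence, tested at 1 uM; a lower number here means a stronger effect, a higher number a weaker effect of the compound at the concentration tested. Compound 1 gives the middle of the three numbers: compound 2 is nearest and compound 3 furthest, and both gaps fall within the scatter, so the three read as alike. Going by the values given here, no pair among them differs in one place only, so no single step can be followed between measured compounds.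

Compound 4, `COc1cc(/C=C/C(=O)/C=C(/C=C/c2ccc(O)c(OC)c2)NCCCO)ccc1O`, has not been measured. It differs from compound 1 by hydroxymethyl in place of hydroxy on a saturated chain carbon, two bonds along the chain from an amine nitrogen. Compound 3 carries the same (3-hydroxypropyl)amino chain on a different core, and its value sits close to that of compound 1, which suggests the chain length alone does not move the read-out far. The step in this assay from compound 1 to compound 4 is therefore expected to be small, with no clear direction beyond the scatter: a number 2.5 percentage points lower from compound 1 to compound 4 (within the scatter). Compound 4 is estimated at 91%, between 80% and 101%.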

Compound 4, a percentage reported as activity, at one concentration (the size of the read-out at that concentration, not a potency): 90.4%
The estimate for compound 4 lay 0.6 percentage points above the measured number, and the stated range covers the measured number.
By their numbers in this assay, from the lowest: compounds 3, 4, 1 and 2 (each within the scatter of the next, the first and the last beyond it).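

Going by these compounds alone, this is the first comparison between two compounds that differ in one place only, so the chain can now be judged on the shared core with nothing else changing. In this assay, going from (2-hydroxyethyl)amino to (3-hydroxypropyl)amino gives a number 3.1 percentage points lower from compound 1 to compound 4 (within the scatter), which means the read-out cannot tell these two chain lengths apart at the concentration tested. Nothing measured here bears on why the read-out behaves this way.

A single step on a single core cannot show whether the same holds for other cores or for larger changes at this position. Going by these compounds, a longer chain such as 4-hydroxybutyl remains open, as does a chain that ends in an amine or a carboxylic acid instead of a hydroxy group.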